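A few compounds are considered here, and "the series" means these few. Any claim that something is new, unique, unknown or untested is made for them only; others in the source may bear on it.

Measured compounds:
- compound 1, `Cc1cccc(C)c1-c1cccc(COc2ccc(CCC(=O)O)nc2)c1`: 71 nM
- compound 2, `Cc1cccc(C)c1-c1cccc(COc2ncc(CCC(=O)O)cn2)c1`: 130 nM
- compound 3, `Cc1cccc(C)c1-c1cccc(COc2ccc(CC(F)C(=O)O)cn2)c1`: 8.6 nM

All three numbers come from a functional assay on CHO cells for agonist activity at Free fatty acid receptor 1 (Homo sapiens), read by calcium flux; a lower number here means that less compound is needed, a higher number that more compound is needed for the effect. Compound 3 gives the lowest number of the three: compound 1 stands a step higher that is beyond the scatter, and compound 2 stands further off still, also beyond the scatter. Within the data shown here, compound 1 and compound 2 differ in their core, and no single-point step between them is described, so only their two values can be set side by side.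

Compound 4, `COC(Cc1ccc(OCc2cccc(-c3c(C)cccc3C)c2)nc1)C(=O)O`, is not yet measured in this assay. It differs from compound 3 in one place: methoxy in place of fluoro on a saturated chain carbon bound to a carbonyl carbon and a saturated chain carbon. Among the measured compounds shown here, the series holds no measured pair with this change, so its effect can only be guessed. The step from compound 1 to compound 3 shows that what sits on this chain carbon matters, so the change is expected to move the number, probably upward, by a moderate step of a 2.6-fold higher number from compound 3 to compound 4 (0.41 log units; beyond the scatter). For compound 4 the expected value in this assay is 22 nM, with a range from 6 nM to 80 nM.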

Compound 4, half-maximal effective concentration: 120 nM
For compound 4 the middle estimate is 5.5-fold (0.74 log units) below the measured one; the measured number lies above the stated range.
By their numbers in this assay, from the lowest: compound 3; then compounds 1, 4 and 2 (each within the scatter of the next).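

In this assay the replacement of fluoro by methoxy on the saturated chain carbon bound to a carbonyl carbon and a saturated chain carbon gives a 14-fold higher number from compound 3 to compound 4 (1.14 log units; beyond the scatter) and is a large step. Among these compounds, this is the first pair that differs in one place only, and it shows directly that the group on this chain carbon can by itself shift the number well beyond the scatter. Nothing at hand bears on what lies behind a step of this size.

Open, going by these compounds, is where a hydroxy, a methyl or an ethoxy on this chain carbon would fall relative to fluoro and methoxy. Also open, on these data alone, are how this chain carbon reads with hydrogen alone on the core of compound 3, and whether the step carries over to the cores of compound 1 and compound 2.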